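The source may hold more compounds than are shown below. What is called first, only, known or untested is meant among the compounds shown, and "the series" means these compounds.

Three nucleoside analogues have so far been tested in a functional assay on CCRF-CEM cells (Homo sapiens), read by MTT assay, with a stated time of 72 h; on this read-out higher numbers stand for weaker inhibition and lower numbers for stronger inhibition. Compound 1 `Cc1ncnc2c1c(-c1cccs1)cn2[C@@H]1O[C@H](CO)[C@@H](O)[C@H]1O` carries a thiophene ring on the shared core; in this assay compound 1 gives > 20000 nM, which is a limit of the assay rather than a number. Compound 2 `O=c1[nH]cnc2c1c(-c1cc3ccccc3o1)cn2[C@@H]1O[C@H](CO)[C@@H](O)[C@H]1O` in this assay gives > 20000 nM, again a limit. Compound 3 `C#Cc1cn([C@@H]2O[C@H](CO)[C@@H](O)[C@H]2O)c2nc(C)nc(N)c12` in this assay gives > 20000 nM, also a limit. Compound 2 therefore stands exactly where every measured compound stands: the limit of > 20000 nM in this assay, at which 3 of the 3 values shown sit, so no numbered value exists among them, and none can be called stronger or weaker than another.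

Compound 4 `O=c1[nH]cnc2c1c(-c1ccccc1)cn2[C@@H]1O[C@H](CO)[C@@H](O)[C@H]1O` is the compound still to be measured. It differs from compound 2 in one place: phenyl in place of 1-benzofuran-2-yl on an aromatic carbon. Among the compounds with values here, no step between two measured compounds is known, so the size of the change this makes cannot be read from the numbers, and the three limits give no hint of direction. The change from compound 2 to compound 4 is therefore expected to be a step that the limit leaves unreadable from compound 2 to compound 4, that is, none beyond the scatter. In this assay compound 4 is estimated to give 30000 nM, within a range of 10000 nM to 100000 nM, most likely reported only as a limit.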

Compound 4, half-maximal inhibitory concentration: > 100000 nM
Compound 4 was reported as a limit (the forecaster's own chance of this, stated with the estimate: 80%); at least 3.3-fold (0.52 log units) between middle value and limit.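

In this assay compound 4 gives > 100000 nM, which is a limit. Compound 2 gives > 20000 nM, also a limit. With only these two limits, no step can be read for phenyl in place of 1-benzofuran-2-yl between compound 2 and compound 4. The compounds shown leave open whether any group on this aromatic carbon gives a numbered value at all.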